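The compounds below may be only part of what the source reports. "The series", "measured", "known", "first", "only" and "open" are said of these compounds alone.

Measured so far:
compound 1, `O=C(/C=C\c1ccc([N+](=O)[O-])cc1)N1N=C(c2ccncc2)OC1c1c[nH]c2ccccc12`, gives > 30 ug/mL
compound 2, `O=C(/C=C\c1ccccc1F)N1N=C(c2ccncc2)OC1c1c[nH]c2ccccc12`, gives > 30 ug/mL
compound 3, `O=C(/C=C\c1cccc(F)c1)N1N=C(c2ccncc2)OC1c1c[nH]c2ccccc12`, gives > 30 ug/mL

In an ADME assay on PANC-1 cells (Homo sapiens) for cytotoxicity, read by MTT assay, with a stated time of 48 h (on this read-out higher numbers stand for weaker inhibition of growth and lower numbers for stronger inhibition of growth), compound 1 reaches no number, only a limit of the assay, > 30 ug/mL. Compound 2 likewise stops at a limit, > 30 ug/mL. Compound 3 also stops at a limit, > 30 ug/mL. Compound 1 therefore stands nowhere on a scale of numbers; it sits at the edge of what this assay can read, and so do its two neighbours.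

Three steps join these compounds, and none can be sized: a step that the two limits leave unreadable from compound 1 to compound 2, a step that the two limits leave unreadable from compound 1 to compound 3 and a step that the two limits leave unreadable from compound 2 to compound 3. The reason is plain, because every value shown sits at the limit of > 30 ug/mL in this assay, at which 3 of the 3 values shown sit.

Compound 4, `O=C(/C=C\c1ccc(Cl)cc1)N1N=C(c2ccncc2)OC1c1c[nH]c2ccccc12`, differs from compound 1 by a single exchange: chloro in place of nitro on an aromatic carbon. For the measured compounds named here, no measured step touches this particular exchange; the steps that are known only swap one aryl group for another and all remain at the limit. On that evidence the expectation is that compound 4 behaves like compound 1 and compound 4 is estimated to show a step that the limit leaves unreadable from compound 1 to compound 4 in this assay. Compound 4 is thus expected to give about 40 ug/mL, most likely again as a limit, with a range from 15 ug/mL to 120 ug/mL.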

Compound 4, concentration for 50% growth inhibition: > 30 ug/mL
Compound 4: no number, only a limit (the forecaster's own chance of this, stated with the estimate: 75%); the middle value lies beyond the limit too.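

Compound 4, like compound 1, compound 2 and compound 3, gives only a limit, so no new step can be read, because all the values stop at the same point: the limit of > 30 ug/mL in this assay, at which 4 of the 4 values shown sit. The compounds shown leave open how strongly any of them inhibits growth in this assay, and whether exchanging these aryl groups changes it.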